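The compounds below may be only part of what the source reports. "The series", "measured", "known", "first", "only" and "open" are said of these compounds alone.

The three measured compounds share one core and differ only in the aryl group on the amide nitrogen. Compound 1 `O=C(CSc1ncnn1-c1ccc(Cl)cc1Cl)Nc1ccccc1Cl` carries a 2-chlorophenyl group there, compound 2 `Cc1ccccc1NC(=O)CSc1ncnn1-c1ccc(Cl)cc1Cl` a 2-methylphenyl group, and compound 3 `Cc1ccc(NC(=O)CSc2ncnn2-c2ccc(Cl)cc2Cl)c(Br)c1` a 2-bromo-4-methylphenyl group. In an ADME assay on MT4 cells (Homo sapiens) for cytotoxicity, read by MTT assay, with a stated time of 5 days (a higher number here means that more compound is tolerated, a lower number that less compound is tolerated), compound 1 gives 29100 nM and compound 2 gives 106000 nM. For compound 3 this assay reports only a limit, > 184000 nM. The change from compound 2 to compound 1 is chloro in place of methyl on an aromatic carbon; it made a 3.6-fold lower number from compound 2 to compound 1 (0.56 log units; beyond the scatter). The two cores of compound 2 and compound 3 differ by 2-bromo-4-methylphenyl in place of 2-methylphenyl on an amide-type nitrogen, which gave an at least 1.7-fold higher number from compound 2 to compound 3 (0.23 log units; that floor lies within the scatter). Between compound 1 and compound 3 the step is an at least 6.3-fold higher number from compound 1 to compound 3 (0.80 log units; beyond the scatter).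

Compound 4 `O=C(CSc1ncnn1-c1ccc(Cl)cc1Cl)Nc1ccc(Cl)cc1Br` has not yet been measured in this assay. It differs from compound 3 by chloro in place of methyl on an aromatic carbon. This is the same kind of change as that from compound 2 to compound 1, though the surroundings differ: there the chloro entered ortho to a large group, whereas in compound 4 it enters meta to a bromo group and para to a large group. Since compound 3 stands only at the limit (the limit of > 184000 nM in this assay, at which 1 of the 3 values shown sits), the starting point for compound 4 is not a number. Compound 4 is expected to show a step of an at least 2.0-fold lower number from compound 3 to compound 4 (0.31 log units; beyond the scatter) in this assay, an expectation resting on the earlier step of a 3.6-fold lower number from compound 2 to compound 1 (0.56 log units; beyond the scatter). The estimated value for compound 4 is therefore 90000 nM, expected to lie between 30000 nM and 250000 nM.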

Compound 4, half-maximal cytotoxic concentration: 189000 nM
Compound 4: middle estimate off by 2.1-fold (0.32 log units), on the low side, within the range that was stated.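

Compound 3 stands only at a limit, so the step to compound 4 cannot be read, and the chloro-for-methyl change cannot be said to have repeated the earlier step on this core, or to have failed to, because the starting point is not a number: the limit of > 184000 nM in this assay, at which 1 of the 4 values shown sits.

In this assay, a 3.6-fold lower number from compound 2 to compound 1 (0.56 log units; beyond the scatter) therefore remains the only readable case of this change, and one case does not show that it carries from one core to another. What can be read is that the 2-bromo-4-chlorophenyl group gives a 6.5-fold higher number from compound 1 to compound 4 (0.81 log units; beyond the scatter), whereas a 1.8-fold higher number from compound 2 to compound 4 (0.25 log units; within the scatter) stays level with the 2-methylphenyl group, so a chloro on this aryl group does not go with a low number in every compound, with compound 1 the low one and compound 4 against it.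

The compounds shown leave open how a plain 2-bromophenyl group would read, which would help to separate the part played by the bromo from that of the chloro or methyl. They also leave open what a methoxy group, an amine or a carboxylic acid would give in place of that chloro or methyl.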